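Trimming the Acyl Chain on a Low-Permeability Series

The source may hold more compounds than are shown below. What is called first, only, known or untested is meant among the compounds shown, and "the series" means these compounds.

Compound 1 `CCC(=O)N1CCC(CN(C2Cc3cc(C#N)ccc3N(Cc3cncn3C)C2)S(=O)(=O)c2ccccn2)CC1` is measured in an ADME assay on Caco-2 cells (Homo sapiens) for permeability, in the apical to basolateral direction (on this read-out lower numbers stand for lower permeability and higher numbers for higher permeability), where compound 1 gives 0.5 10^-6 cm/s. Two neighbours share its core and differ only in the group on the carbonyl carbon: compound 2 `Cn1cncc1CN1CC(N(CC2CCN(C(=O)C3CC3)CC2)S(=O)(=O)c2ccccn2)Cc2cc(C#N)ccc21` gives 0.5 10^-6 cm/s in this assay, and compound 3 `Cn1cncc1CN1CC(N(CC2CCN(C(=O)c3ccco3)CC2)S(=O)(=O)c2ccccn2)Cc2cc(C#N)ccc21` gives 0.5 10^-6 cm/s. The measured steps are flat: no change at the digits printed from compound 1 to compound 2 (within the scatter), no change at the digits printed from compound 1 to compound 3 (within the scatter) and no change at the digits printed from compound 2 to compound 3 (within the scatter). Compound 1 therefore stands level with compounds 2 and 3 on the numbers shown, with no compound separated from another beyond the scatter.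

Compound 4 `CC(=O)N1CCC(CN(C2Cc3cc(C#N)ccc3N(Cc3cncn3C)C2)S(=O)(=O)c2ccccn2)CC1` differs from compound 1 by hydrogen in place of methyl on a saturated chain carbon bound to a carbonyl carbon. The three measured steps all bear on this change, since each of them also alters the group on the carbonyl carbon, and none of them moved the read-out. On that basis, compound 4 is expected to show no step beyond the scatter, no change at the digits printed from compound 1 to compound 4 (within the scatter). For compound 4 the estimate in this assay is 0.5 10^-6 cm/s, with an expected range from 0.2 10^-6 cm/s to 1.2 10^-6 cm/s.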

Compound 4, apparent permeability: 0.5 10^-6 cm/s
The estimate for compound 4 equals the measured number at the digits printed, and the stated range covers the measured number.
By their numbers in this assay, from the lowest: compounds 1, 2, 3 and 4 (each within the scatter of the next).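

Cutting ethyl back to methyl on the carbonyl carbon gives no change at the digits printed from compound 1 to compound 4 (within the scatter) in this assay and so extends the flat picture to a change that only shortens the chain, propanoyl to acetyl, with no ring entering. Acetyl also stands level with the two ring-bearing acyl groups, with no change at the digits printed from compound 3 to compound 4 (within the scatter) and no change at the digits printed from compound 2 to compound 4 (within the scatter) on the same read-out, so methyl, ethyl, cyclopropyl and furan-2-yl on the carbonyl carbon are not separated in these four compounds, and none of them goes against this. No measurement is available that would account for this flatness.

From the compounds shown here alone, whether an amine or a carboxylic acid on the carbonyl carbon, or a longer chain such as hexanoyl, would stay level with these four remains open. So does whether a change elsewhere on the shared core would move the read-out.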